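Sulfonyl Aryl Exchange on a Shared Core: Compound 3

The compounds below may be only part of what the source reports. "The series", "measured", "known", "first", "only" and "open" are said of these compounds alone.

Measured compounds:
compound 1, `CC1CCN(c2c(S(=O)(=O)c3ccc(F)cc3)cnc3cc(Cl)ccc23)CC1`, 91%
compound 2, `Cc1ccc(S(=O)(=O)c2cnc3cc(Cl)ccc3c2N2CCC(C)CC2)cc1Cl`, 89%

Of the compounds shown here, two have been measured in an assay on isolated protein for displacement of a labelled ligand from metabotropic glutamate receptor 5 (Homo sapiens), with a stated time of 60 min, tested at 1 uM; a lower number here means less inhibition, a higher number more inhibition at the concentration tested (going by the name of the read-out). Compound 1 `CC1CCN(c2c(S(=O)(=O)c3ccc(F)cc3)cnc3cc(Cl)ccc23)CC1` gives 91%, and compound 2 `Cc1ccc(S(=O)(=O)c2cnc3cc(Cl)ccc3c2N2CCC(C)CC2)cc1Cl` gives 89%. Compound 2 holds the lower of the two numbers, with compound 1 as its nearest neighbour, and the step of a number 2 percentage points lower from compound 1 to compound 2 (within the scatter) lies within the scatter, so no order between the two can be read from it.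

Compound 3 `COc1ccc(S(=O)(=O)c2cnc3cc(Cl)ccc3c2N2CCC(C)CC2)cc1OC` has not yet been measured. It differs from compound 2 in one place: 3,4-dimethoxyphenyl in place of 3-chloro-4-methylphenyl on a sulfonyl sulfur. Going by the values given here, only one measured step bears on this position. That step, a number 2 percentage points lower from compound 1 to compound 2 (within the scatter), concerns the same sulfonyl sulfur and shows that an exchange of the aryl group there left the number within the scatter. It does not involve the 3,4-dimethoxyphenyl group itself, so it is an indirect guide. The step expected for compound 3 is a number 11 percentage points lower from compound 2 to compound 3 (beyond the scatter), a small downward movement with a wide range in the absence of a direct precedent. Compound 3 is estimated at 78%, between 45% and 95%.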

Compound 3, a percentage reported as inhibition, at one concentration (the size of the read-out at that concentration, not a potency): 93%
Compound 3: middle estimate off by 15 percentage points, on the low side, within the range that was stated.
By their numbers in this assay, from the lowest: compounds 2, 1 and 3 (each within the scatter of the next).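

In this assay, 3,4-dimethoxyphenyl in place of 3-chloro-4-methylphenyl on a sulfonyl sulfur gives a number 4 percentage points higher from compound 2 to compound 3 (within the scatter), while the same group in place of 4-fluorophenyl gives a number 2 percentage points higher from compound 1 to compound 3 (within the scatter), so no order among the three compounds can be read. Going by these compounds alone, the earlier step had covered only two halogen-bearing aryl groups, whereas this change brings in a group without halogen, with 10 heavy atoms against 8 and 2 hydrogen-bond acceptors against 0, and the number still stays within the scatter. Nothing shown accounts for the number staying level or ties it to any feature of the groups.

Each read-out gives the size of the inhibition at one concentration and not a potency, so this assay leaves open whether compound 1, compound 2 and compound 3 would differ in a full concentration series. Going by these compounds, it also remains open whether the number would hold with an amine or a carboxylic acid on the aryl ring, or with a plain alkyl chain in place of the aryl group on the sulfonyl sulfur.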